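Amide-nitrogen aryl swap: notes toward compound 3

The source may report more compounds than this note shows. Statements on the series, on what has been measured and on what is new or still open speak of the compounds shown alone.

Measured in a functional assay on HCT-116 cells (Homo sapiens) for inhibition, read by MTT assay, with a stated time of 72 h; a higher number here means a weaker inhibitor, a lower number a stronger inhibitor:
compound 1 `COc1ccccc1NC(=O)c1ccc(/N=N\c2c[nH]c3ccccc23)cc1`, compound 1 gives 122000 nM
compound 2 `O=C(Nc1ccccc1F)c1ccc(/N=N\c2c[nH]c3ccccc23)cc1`, compound 2 gives 559000 nM

Among the measured compounds shown here, compound 2 stands highest of the two numbers; the single known step is a 4.6-fold higher number from compound 1 to compound 2 (0.66 log units; beyond the scatter). Compound 3 `O=C(Nc1cccc([N+](=O)[O-])c1)c1ccc(/N=N\c2c[nH]c3ccccc23)cc1` differs from compound 2 by 3-nitrophenyl in place of 2-fluorophenyl on an amide-type nitrogen. For the measured compounds named here, no measured step matches this change; the one step known alters the group on an aromatic carbon of the same aryl, so it bears only loosely. Compound 3 is therefore expected to sit near compound 2, with the step of a 1.2-fold lower number from compound 2 to compound 3 (0.09 log units; within the scatter) expected not beyond the scatter. The estimate for compound 3 is 450000 nM, range 120000 nM to 1500000 nM.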

Compound 3, half-maximal inhibitory concentration: 70100 nM
The estimate for compound 3 lay 6.4-fold (0.81 log units) above the measured number; the whole stated range lies above it.
By their numbers in this assay, from the lowest: compounds 3 and 1 (each within the scatter of the next); then compound 2.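

At the amide-type nitrogen, 3-nitrophenyl in place of 2-fluorophenyl moves the number in this assay well beyond the scatter (an 8.0-fold lower number from compound 2 to compound 3 (0.90 log units; beyond the scatter)), so the aryl at this position can change the read-out without a change to the shared core. Against 2-methoxyphenyl, the same group gives no separation (a 1.7-fold lower number from compound 1 to compound 3 (0.24 log units; within the scatter)), leaving compound 2 alone at the weak end. No evidence on the origin of these steps is at hand.

Still open, going by these compounds, is whether the nitro group or its ring position drives the step, since both differ here. On these data alone, how a 3-aminophenyl or 3-carboxyphenyl group would read at this nitrogen also remains unknown.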